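The source may hold more compounds than are shown below. What is called first, only, known or untested is meant among the compounds shown, and "the series" means these compounds.

Measured so far:
- compound 1, `CNC(=O)c1cc(C(=O)NC2CCC2)cn(Cc2ccncc2)c1=O`: 1.7
- compound 2, `CNC(=O)c1cccn(Cc2ccccc2)c1=O`: 3
- compound 3, `CNC(=O)c1cc(C(=O)NC2CC2)cn(CC2CCOCC2)c1=O`: 1.5

In a physicochemical assay for lipophilicity, at pH 7.4 (on this read-out lower numbers stand for lower lipophilicity and higher numbers for higher lipophilicity), compound 2 stands highest of the three numbers; compound 1 lies nearest, and compound 3 furthest, both beyond the scatter. Compound 4, `CNC(=O)c1cc(C(=O)NCC(C)C)cn(Cc2ccccc2)c1=O`, is not yet measured. Its change from compound 2 is isobutylcarbamoyl in place of hydrogen on an aromatic carbon. Going by the values given here, compound 1 and compound 3 also carry a carbamoyl group on that position, but their other substituent differs from the benzyl group shared by compound 2 and compound 4, so no step between measured compounds sets the size here. For compound 4 the step of a number 0.10 log units lower from compound 2 to compound 4 (within the scatter) is expected to be small, likely within the scatter, perhaps slightly downward. Compound 4 is estimated at 2.9, within 2.3 to 3.5.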

Compound 4, distribution coefficient: 4.3
Beside the measured number, compound 4's estimate is 1.40 log units below it; measured number outside the range, above it.
By their numbers in this assay, from the lowest: compounds 3 and 1 (each within the scatter of the next); then compound 2; then compound 4.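

In this assay, going by these compounds alone, the aromatic carbon two atoms from the ring nitrogen responds strongly to substitution: with the benzyl group held constant, isobutylcarbamoyl in place of hydrogen gives a number 1.30 log units higher from compound 2 to compound 4 (beyond the scatter) as the first directly readable step at this position. No measurement shown accounts for the size of this step.

From the compounds shown here alone, whether the step belongs to the carbamoyl link or to the isobutyl chain stays open. A carboxylic acid, an amine or an unsubstituted carboxamide on the same carbon, with the benzyl group kept, would separate the two.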